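Trifluoromethyl in place of methoxy: expected clearance

A few compounds are considered here, and "the series" means these few. Any claim that something is new, unique, unknown or untested is made for them only; others in the source may bear on it.

Among the measured compounds shown here, compound 2 `COc1ccc(C[C@H]2CC[C@](O)(Cc3cc(-c4cn[nH]c4)on3)CC2)cc1` gives 61.8 mL/min/kg in an ADME assay on the whole organism (strain Sprague-Dawley) for pharmacokinetics, with Rattus norvegicus as the target, using cassette dosing (a higher number here means faster removal of the compound, a lower number slower removal), and holds the higher of the two numbers so far. Compound 1 `O[C@]1(Cc2cc(-c3cn[nH]c3)on2)CC[C@H](Cc2ccc(F)cc2)CC1` gives 30 mL/min/kg in this assay as the nearest value. Compound 3 `O[C@]1(Cc2cc(-c3cn[nH]c3)on2)CC[C@H](Cc2ccc(C(F)(F)F)cc2)CC1` has trifluoromethyl in place of methoxy on an aromatic carbon and this group stays para to a large group. For the measured compounds named here, only one measured step bears on this place: a 2.1-fold higher number from compound 1 to compound 2 (0.31 log units; beyond the scatter) with methoxy in place of fluoro, a modest step beyond the scatter. Methoxy leaves again in compound 3, but no measured compound carries trifluoromethyl, so the guide is thin. A fall of similar size is expected, and the expected step is a 2.1-fold lower number from compound 2 to compound 3 (0.31 log units; beyond the scatter) in this assay on this reading. For compound 3 the estimated value is 30 mL/min/kg (range 15 mL/min/kg to 60 mL/min/kg).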

Compound 3, clearance: 4 mL/min/kg
The estimate for compound 3 lay 7.5-fold (0.88 log units) above the measured number, and the stated range ends above it.
By their numbers in this assay, from the lowest: compound 3; then compound 1; then compound 2.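

Notes on the aromatic position para to a large group: in this assay this position spans a wider range than the first pair showed, with trifluoromethyl in place of methoxy giving a 15-fold lower number from compound 2 to compound 3 (1.19 log units; beyond the scatter) and trifluoromethyl in place of fluoro giving a 7.5-fold lower number from compound 1 to compound 3 (0.88 log units; beyond the scatter) on the same core. Losing methoxy therefore does not simply return the number to the level of the fluoro compound, as the incoming group matters as well. Among these three compounds, fluoro falls between methoxy and trifluoromethyl, and every step is beyond the scatter. Nothing available bears on what lies behind the size of these steps.

Where chloro, a nitrile or an amine at this place would fall in this assay stays open. Going by these compounds, it is also open whether the low number of compound 3 would hold with changes elsewhere on the core.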